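The source may report more compounds than this note shows. Statements on the series, on what has been measured and on what is new or still open speak of the compounds shown alone.

Working notes on the series. In a functional assay on A549 cells (Homo sapiens) for antiproliferative activity, read by MTT assay, with a stated time of 72 h (a lower number here means a stronger inhibitor, a higher number a weaker inhibitor), compound 3 `NS(=O)(=O)c1ccc(NC(=S)Nc2ccc3ncnc(Nc4ccc(Cl)c(C(F)(F)F)c4)c3c2)cc1` gives 4500 nM, the lowest of the numbers shown. Compound 1 `COc1cc2ncnc(Nc3cccc(Cl)c3F)c2cc1OCCCCC(=O)Nc1ccc(S(N)(=O)=O)cc1` gives 10500 nM in this assay. For compound 2 `C#Cc1cccc(Nc2ncnc3ccc(NC(=S)Nc4ccc(S(N)(=O)=O)cc4)cc23)c1` this assay returns only a limit, > 40000 nM. Among the compounds with values here, the one step with a number, an at least 8.8-fold lower number from compound 2 to compound 3 (0.94 log units; beyond the scatter), concerns the same nitrogen, and one side of it is a limit (the limit of > 40000 nM in this assay, at which 1 of the 3 values shown sits). Compound 4 `NS(=O)(=O)c1ccc(NC(=S)Nc2ccc3ncnc(Nc4ccc(C(F)(F)F)cc4)c3c2)cc1` differs from compound 3 as follows: 4-(trifluoromethyl)phenyl in place of 4-chloro-3-(trifluoromethyl)phenyl on a nitrogen on an aromatic ring. Within the data shown here, no measured step removes a chlorine alone; the only guide is the step at this nitrogen, where the aryl group mattered strongly. The expectation for compound 4 is therefore a small loss, a 1.6-fold higher number from compound 3 to compound 4 (0.19 log units; within the scatter), within or close to the scatter. Compound 4 is expected to give 7000 nM, between 2500 nM and 20000 nM.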

Compound 4, half-maximal inhibitory concentration: > 40000 nM
Compound 4 gave a limit, no number; the forecaster's own chance of this, stated with the estimate: 10%; middle value at least 5.7-fold (0.75 log units) away from the limit.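

Removing the chlorine alone from the aryl group on this nitrogen gives an at least 8.8-fold higher number from compound 3 to compound 4 (0.94 log units; beyond the scatter) in this assay, so the trifluoromethyl group alone does not hold the number reached by compound 3. The reading of compound 4 is a limit of the assay, so the loss has only a lower bound. The step between compound 2 and compound 4 cannot be read, since both are limits: the limit of > 40000 nM in this assay, at which 2 of the 4 values shown sit.

On these data alone, whether a bromine or a methyl in place of the chlorine keeps the number of compound 3 stays open. So does the effect of the chlorine without the trifluoromethyl group.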